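Removing the (1-bromoethenyl)carbonyl group: notes on compounds 1 to 4

The source may report more compounds than this note shows. Statements on the series, on what has been measured and on what is new or still open speak of the compounds shown alone.

Measured in a functional assay on FM3A cells (Mus musculus) for antiproliferative activity, with a stated time of 48 h; a lower number here means a stronger inhibitor, a higher number a weaker inhibitor:
compound 1 `C=C(Br)C(=O)Nc1ccc(/C=C/C(=O)c2ccc(Cl)c(Cl)c2)cc1` gives 3200 nM
compound 2 `C=C(Br)C(=O)Nc1ccc(/C=C/C(=O)c2cc(OC)c(OC)c(OC)c2)cc1` gives 950 nM
compound 3 `Nc1ccc(/C=C/C(=O)c2ccc(Cl)c(Cl)c2)cc1` gives 33000 nM

Compound 2 has the lowest number of the three; compound 1 stands nearer to it and compound 3 furthest, both beyond the scatter. The difference between the core of compound 1 and the core of compound 2 is not broken down here.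

One change is observed once and is now repeated. From compound 1 to compound 3 the change is hydrogen in place of (1-bromoethenyl)carbonyl on a nitrogen on an aromatic ring, and in this assay it gives a 10-fold higher number from compound 1 to compound 3 (1.01 log units; beyond the scatter). Compound 4 `COc1cc(C(=O)/C=C/c2ccc(N)cc2)cc(OC)c1OC` is not yet measured. It differs from compound 2 by hydrogen in place of (1-bromoethenyl)carbonyl on a nitrogen on an aromatic ring; the place lines of both changes read the same, so this is the same change on a second core.

For compound 4 a step of similar size is expected, a 10-fold higher number from compound 2 to compound 4 (1.00 log units; beyond the scatter), because compound 1 to compound 3 showed a 10-fold higher number from compound 1 to compound 3 (1.01 log units; beyond the scatter). Compound 4 is therefore estimated at 9500 nM, with a range from 3000 nM to 30000 nM; whether the second core carries the change equally remains to be seen.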

Compound 4, half-maximal inhibitory concentration: 36000 nM
For compound 4 the middle estimate is 3.8-fold (0.58 log units) below the measured one, outside the stated range (above it).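

In this assay the same removal of the (1-bromoethenyl)carbonyl group gives a 38-fold higher number from compound 2 to compound 4 (1.58 log units; beyond the scatter) on the second core, a large step in the same direction as on the core of compound 1. Set side by side, the two steps agree in direction but differ in size: the same change on two cores in this assay, a 10-fold higher number (1.01 log units; beyond the scatter) from compound 1 to compound 3 and a 38-fold higher number (1.58 log units; beyond the scatter) from compound 2 to compound 4, 3.7-fold (0.57 log units) apart, beyond the scatter of two such steps. The direction of this change therefore held on both cores shown, but its size did not carry over as a fixed amount, and two cores do not show which feature of a core sets that size.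

The compounds shown leave open which part of the (1-bromoethenyl)carbonyl group accounts for the steps, since only that whole group and the bare amino form appear. An acetyl or a propenoyl group on a nitrogen on an aromatic ring, set on both cores, would show whether the size of the step still depends on the core when the bromine or the double bond is gone.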